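The source may hold more compounds than are shown below. What is called first, only, known or untested is meant among the compounds shown, and "the series" means these compounds.

The series shares one core; compound 1 is `COC(=O)[C@@]1(C)CCC=C2[C@@H]1CC[C@@H](C)[C@]2(C)Cc1c(C)[nH]c2ccccc12`. In a functional assay on HBL-100 cells (Homo sapiens) for inhibition, read by sulforhodamine B assay, with a stated time of 48 h (a lower number here means a stronger inhibitor of growth, a higher number a weaker inhibitor of growth), compound 1 gives 14000 nM. Two further measured compounds carry a halogen on an aromatic carbon: compound 2, `COC(=O)[C@@]1(C)CCC=C2[C@@H]1CC[C@@H](C)[C@]2(C)Cc1c(C)[nH]c2ccc(Br)cc12`, gives 15000 nM in this assay, and compound 3, `COC(=O)[C@@]1(C)CCC=C2[C@@H]1CC[C@@H](C)[C@]2(C)Cc1c(C)[nH]c2ccc(Cl)cc12`, gives 15000 nM. On these numbers compound 1 stands within the scatter of both neighbours: a 1.1-fold higher number from compound 1 to compound 2 (0.03 log units; within the scatter), and a 1.1-fold higher number from compound 1 to compound 3 (0.03 log units; within the scatter), while no change at the digits printed from compound 2 to compound 3 (within the scatter). The three numbers cannot be told apart.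

Compound 4 is `COC(=O)[C@@]1(C)CCC=C2[C@@H]1CC[C@@H](C)[C@]2(C)Cc1c(C)[nH]c2c(Cl)cccc12`; it has not yet been measured in this assay. Relative to compound 1 the change is chloro in place of hydrogen on an aromatic carbon. Among the compounds with values here, the steps that bear on this are the two halogen additions on an aromatic carbon, from compound 1 to compound 2 and from compound 1 to compound 3, both within the scatter, together with the bromine-for-chlorine exchange from compound 2 to compound 3, also within the scatter. Within the data shown here, the chlorine of compound 4 enters at a place for which no measured step exists; the expectation can rest only on the halogens leaving the number unchanged elsewhere on the ring. Compound 4 is therefore expected to show no step beyond the scatter, a 1.1-fold higher number from compound 1 to compound 4 (0.03 log units; within the scatter). The estimate for compound 4 in this assay is 15000 nM, with a range of 7000 nM to 32000 nM.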

Compound 4, concentration for 50% growth inhibition: 22000 nM
Beside the measured number, compound 4's estimate is 1.5-fold (0.17 log units) below it; the range from low to high includes it.
By their numbers in this assay, from the lowest: compounds 1, 2, 3 and 4 (each within the scatter of the next).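

Chloro in place of hydrogen at this place, on an aromatic carbon ortho to a fused ring and meta to a fused ring, gives the first reading there in this assay: a 1.6-fold higher number from compound 1 to compound 4 (0.20 log units; within the scatter). Within the data shown here, the halogen steps from the earlier compounds lay at a different place on the ring, so the result extends the finding of no step beyond the scatter to a second place on that ring, though this step is larger than those earlier steps and still stays inside the scatter. Moving chloro between the two places shows no separable difference, since compound 3 gives 15000 nM and compound 4 gives 22000 nM, values that lie within the scatter of each other, and no outside measurement bears on this result.

The compounds shown leave open whether anything at this place can shift the number beyond the scatter, as only chloro has been seen there and an amine, a carboxylic acid or a longer chain could behave differently. They also leave open whether bromo at this place would match chloro, and whether the methyl ester of the shared core matters, which a carboxylic acid in its stead would test.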